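Plasma stability notes: isopentyl for cyclobutyl on the ring nitrogen

This account rests on a few compounds, and the source may have more. Where it says the series, first, only, none or still open, it means among the compounds named here.

Measured so far:
- compound 1 `O=C(O)c1cc(-c2cccc(COc3ccc4c(=O)n(C5CCC5)sc4c3)c2)ccc1Cl`: 91%
- compound 2 `O=C1c2ccc(OCc3cccc(-c4ccc(C(F)(F)F)cc4F)c3)cc2CN1C1CCCC1`: "not determined" (no result reported)
- compound 3 `COc1ccc(-c2cccc(COc3ccc4c(c3)CN(C3CCCC3)C4=O)c2)cc1C(=O)O`: 100%

The series is followed in an ADME assay on a cell-free system (plasma, Rattus norvegicus) for metabolic stability, read by LC-MS, with a stated time of 1 h, at 37 degrees C, tested at 100 uM; a higher number here means that more of the compound is left, a lower number that less of the compound is left. Compound 1 gives 91% in this assay, the lower of the two numbers reported; the nearest value is that of compound 3, which gives 100%, a gap that lies within the usual scatter of this assay, so the two are not distinguished. For compound 2 no result was reported, and its value reads "not determined" (no result reported).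

The next compound, compound 4 `CC(C)CCn1sc2cc(OCc3cccc(-c4ccc(Cl)c(C(=O)O)c4)c3)ccc2c1=O`, differs from compound 1 in a single place: isopentyl in place of cyclobutyl on an aromatic nitrogen. The rest of the molecule, including the acid-bearing ring system and the shared core, is unchanged.

Among the compounds with values here, no step between two measured compounds is available to calibrate this change. With both measured values high and close to each other, no direction is indicated, and the expected change in this assay is none beyond the scatter; the estimate puts the step at a number 1 percentage points lower from compound 1 to compound 4 (within the scatter). Compound 4 is therefore expected to give 90% in this assay, with a range from 75% to 100%, the high end being bounded by complete recovery.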

Compound 4, percent of the compound remaining: 91%
Compound 4: middle estimate off by 1 percentage points, on the low side; measured number inside the range.
By their numbers in this assay, from the lowest: compounds 1, 4 and 3 (each within the scatter of the next).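

In this assay, the first step measured at this position, isopentyl in place of cyclobutyl on an aromatic nitrogen, reads no change at the digits printed from compound 1 to compound 4 (within the scatter). The earlier compounds shown here offered no step at all, and this one shows that, on the shared core and with the acid-bearing ring system unchanged, the four-membered carbon ring can give way to an open chain without the number leaving the scatter. Nothing at hand explains this result, and no measurement on these compounds speaks to why the value holds.

Open, from the compounds shown here alone, is whether a different kind of group on this nitrogen, such as a longer chain, a chain ending in an amine, or one carrying a hydroxyl group, would move the number in this assay beyond the scatter. Also open, going by these compounds, is whether the same exchange would read the same way on another core, as this single step comes from one pair of compounds, and it says nothing about how far this position can be varied.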